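This account rests on a few compounds, and the source may have more. Where it says the series, first, only, none or still open, it means among the compounds named here.

Compound 2 `CO[C@@H]1CC=C2NN(c3ccc(Cl)cc3)C(=O)C[C@]2(C)O1` gives 31700 nM in a functional assay on SK-N-SH cells (Homo sapiens) for inhibition, read by sulforhodamine B assay, with a stated time of 48 h (a lower number here means a stronger inhibitor, a higher number a weaker inhibitor), the higher of the two numbers on hand; compound 1 `CO[C@@H]1CC=C2NN(c3cc4ccccc4[nH]3)C(=O)C[C@]2(C)O1` gives 19500 nM in this assay, and the two values lie within the scatter of each other, so no order between them is read. Compound 3 `CO[C@@H]1CC=C2NN(c3cccnc3)C(=O)C[C@]2(C)O1` carries pyridin-3-yl in place of 4-chlorophenyl on an amide-type nitrogen in a ring. Among the measured compounds shown here, no measured pair shows this change, so the step is expected to be small, from compound 2 to compound 3 estimated as a 1.3-fold higher number from compound 2 to compound 3 (0.10 log units; within the scatter), no firm direction beyond the scatter. Compound 3 is therefore estimated at 40000 nM, between 12000 nM and 130000 nM.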

Compound 3, half-maximal inhibitory concentration: 19000 nM
Compound 3: middle estimate off by 2.1-fold (0.32 log units), on the high side; the range from low to high includes it.
By their numbers in this assay, from the lowest: compounds 3, 1 and 2 (each within the scatter of the next).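

In this assay, pyridin-3-yl in place of 4-chlorophenyl on the amide-type nitrogen in a ring gives a 1.7-fold lower number from compound 2 to compound 3 (0.22 log units; within the scatter). This first measured step at this position stays within the scatter, so exchanging a carbon-only aromatic ring with chlorine for one with a ring nitrogen does not separate the two compounds. No supporting data bear on this result.

Still open, from the compounds shown here alone, is whether any group here gives a step beyond the scatter. A carboxylic acid on the aromatic ring, or an open alkyl chain replacing that ring, would test this.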